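A few compounds are considered here, and "the series" means these few. Any claim that something is new, unique, unknown or untested is made for them only; others in the source may bear on it.

Three analogues built on one shared core have been examined in a functional assay on CCRF-CEM cells (Homo sapiens) for antiproliferative activity (on this read-out higher numbers stand for weaker inhibition and lower numbers for stronger inhibition), differing only in the aryl group attached to the five-membered aromatic ring with 1 sulfur. Compound 1 `COc1cc(C(=O)c2sc(-c3ccc(-c4ccccc4)cc3)cc2N)cc(OC)c1OC` carries a biphenyl group there; in this assay its result is only a limit, > 10000 nM. Compound 2 `COc1cc(C(=O)c2sc(-c3ccncc3)cc2N)cc(OC)c1OC` bears pyridin-4-yl and in this assay gives 110 nM, which is the highest of the two numbers actually reported. Within the data shown here, its nearest neighbour is compound 3 `COc1cc(C(=O)c2sc(-c3ccccc3Cl)cc2N)cc(OC)c1OC`, which in this assay gives 16 nM; the change a 6.9-fold lower number from compound 2 to compound 3 (0.84 log units; beyond the scatter) is the only fully quantified step in the set.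

Compound 4 `CCOc1ccc(-c2cc(N)c(C(=O)c3cc(OC)c(OC)c(OC)c3)s2)cc1` has not yet been measured. Relative to compound 2 it changes by 4-ethoxyphenyl in place of pyridin-4-yl on an aromatic carbon. Among the measured compounds shown here, the one measured step that bears on this move is the one from compound 2 to compound 3, where replacing pyridin-4-yl by a carbocyclic aryl group lowered the number beyond the scatter. Compound 1, also carrying a carbocyclic aryl group with an additional substituent, sits at a limit (the limit of > 10000 nM in this assay, at which 1 of the 3 values shown sits), which tempers that expectation. On balance a modest decrease is expected: the step from compound 2 to compound 4 is estimated at a 2.8-fold lower number from compound 2 to compound 4 (0.44 log units; beyond the scatter). Compound 4 is therefore expected to give about 40 nM in this assay, within a range from 6 nM to 300 nM.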

Compound 4, half-maximal inhibitory concentration: 270 nM
For compound 4 the middle estimate is 6.8-fold (0.83 log units) below the measured one, and the stated range covers the measured number.
By their numbers in this assay, from the lowest: compound 3; then compound 2; then compound 4. At a limit, above all of these: compound 1.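

At this position, on the aromatic carbon next to the ring sulfur, a six-membered aromatic ring of carbon only does not by itself lower the number in this assay: 4-ethoxyphenyl in place of pyridin-4-yl gives a 2.5-fold higher number from compound 2 to compound 4 (0.39 log units; beyond the scatter), the opposite direction to the step seen with 2-chlorophenyl. The contrast between the two carbon-only aryl groups is larger, with a 17-fold higher number from compound 3 to compound 4 (1.23 log units; beyond the scatter), so in these compounds the result depends on what that ring carries and where, and not only on whether the ring holds a nitrogen. Ethoxy in place of phenyl gives an at least 37-fold lower number from compound 1 to compound 4 (1.56 log units; beyond the scatter), a step that is only a bound because the result for compound 1 is a limit: the limit of > 10000 nM in this assay, at which 1 of the 4 values shown sits.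

Compound 3 and compound 4 differ in both the substituent and its location on the ring, so the compounds shown leave open which of the two accounts for the gap between them. An unsubstituted phenyl, 4-chlorophenyl or 2-ethoxyphenyl group on this carbon would separate those two contributions, and a 4-methoxyphenyl group would show whether the length of the ethoxy chain matters.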